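Moving the Chlorine on the Anilide: Estimating Compound 4

The source may report more compounds than this note shows. Statements on the series, on what has been measured and on what is new or still open speak of the compounds shown alone.

Measured so far in a physicochemical assay for lipophilicity, using the shake flask method, in phosphate buffer, measured as octanol-water partition, at pH 7.4; on this read-out higher numbers stand for higher lipophilicity and lower numbers for lower lipophilicity:
- compound 1 `COc1cc(-c2cc(C(=O)O)c3ccccc3n2)ccc1OCC(=O)Nc1ccccc1F`: 0.9
- compound 2 `COc1cc(-c2cc(C(=O)O)c3ccccc3n2)ccc1OCC(=O)Nc1ccc(F)cc1`: 1.1
- compound 3 `COc1cc(-c2cc(C(=O)O)c3ccccc3n2)ccc1OCC(=O)Nc1ccccc1Cl`: 1.6

The three compounds share one core and differ only in the halogen-bearing phenyl group on the amide nitrogen. Compound 3 stands highest of the three in this assay. Two measured steps show this: a number 0.50 log units higher from compound 2 to compound 3 (beyond the scatter), and a number 0.70 log units higher from compound 1 to compound 3 (beyond the scatter).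

Compound 4 `COc1cc(-c2cc(C(=O)O)c3ccccc3n2)ccc1OCC(=O)Nc1ccc(Cl)cc1` has not yet been measured. It has 4-chlorophenyl in place of 2-chlorophenyl on an amide-type nitrogen.

The closest parallel is the matching change among the fluoro compounds, 4-fluorophenyl in place of 2-fluorophenyl, which gave a number 0.20 log units higher from compound 1 to compound 2 (within the scatter). This is a single pair, so it suggests a direction without establishing a rule. A second route starts from compound 2 and adds the chloro-for-fluoro change seen in a number 0.70 log units higher from compound 1 to compound 3 (beyond the scatter), and it leads to nearly the same place. Both routes point to a small rise, so the expected result is a number 0.20 log units higher from compound 3 to compound 4 (within the scatter).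

Compound 4 is estimated at 1.8, with an expected range from 1.4 to 2.2.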

Compound 4, distribution coefficient: 1.5
Compound 4: the middle estimate sits 0.30 log units above what was measured, within the range that was stated.
By their numbers in this assay, from the lowest: compounds 1 and 2 (each within the scatter of the next); then compounds 4 and 3 (each within the scatter of the next).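

In this assay, exchanging 2-chlorophenyl for 4-chlorophenyl on the amide-type nitrogen gives a step within the scatter (a number 0.10 log units lower from compound 3 to compound 4 (within the scatter)), so the chloro pair behaves like the fluoro pair (a number 0.20 log units higher from compound 1 to compound 2 (within the scatter)): on this read-out, neither pair separates the two named phenyl groups. The kind of halogen gives the clearer separation, since the chloro-for-fluoro change among the 4-substituted phenyl groups gives a step beyond the scatter (a number 0.40 log units higher from compound 2 to compound 4 (beyond the scatter)), as it did among the 2-substituted ones (a number 0.70 log units higher from compound 1 to compound 3 (beyond the scatter)), and the mixed change from 2-fluorophenyl to 4-chlorophenyl also lies beyond it (a number 0.60 log units higher from compound 1 to compound 4 (beyond the scatter)); among these four compounds, no pair goes against this pattern. Nothing shown here gives a reason for these steps.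

The compounds shown leave open whether a bromo group, a methyl group or an amine on the phenyl ring would follow the same pattern. They also leave open whether these steps would keep their size if the carboxylic acid on the shared core gave way to its methyl ester.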